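The compounds below may be only part of what the source reports. "The series", "measured", "known", "first", "only" and "open" are said of these compounds alone.

Compound 1 `Cc1c(O)ccc2c1[C@H](Cn1cc(-c3ccccc3)nn1)[C@@]13CC(=O)[C@@](C)(CC[C@@H]21)C3`: > 20000 nM
Compound 2 `C=C1C[C@]23C[C@@]1(O)CC[C@H]2c1ccc(O)c(C)c1[C@@H]3Cn1cc(-c2ccccc2)nn1`: > 20000 nM

Of the compounds shown here, two have been tested in a functional assay on HL-60 cells (Homo sapiens) for cytotoxicity, read by MTT assay, with a stated time of 4 days; a higher number here means a weaker inhibitor, a lower number a stronger inhibitor. Compound 1 returns > 20000 nM in this assay, which is a limit of the assay and not a measured number. Compound 2 likewise returns > 20000 nM in this assay, again a limit. Going by the values given here, compound 1 therefore stands on no number at all: what is known of it is a limit, and the one further value shown is a limit as well, so that both values sit at the limit of > 20000 nM in this assay, at which 2 of the 2 values shown sit. Among the compounds with values here, no step between two measured compounds can be drawn from such data, and nothing can be said about which of the two is the stronger.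

The next compound to be measured is compound 3 `Cc1c(O)ccc2c1[C@H](Cn1cc(-c3ccc(C(F)(F)F)cc3)nn1)[C@@]13CC(=O)[C@@](C)(CC[C@@H]21)C3`. It differs from compound 1 in one place: trifluoromethyl in place of hydrogen on an aromatic carbon. Within the data shown here, since the only value known for compound 1 is the limit > 20000 nM, there is no measured step on which to base a direction. The expected step of a number no higher from compound 1 to compound 3 (the limit leaves the size open) is accordingly none beyond the scatter, with the result most probably reported once more as a limit. Compound 3 is expected to give about 20000 nM in this assay, somewhere between 7000 nM and 60000 nM.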

Compound 3, half-maximal inhibitory concentration: > 20000 nM
Compound 3 ended at the assay's limit; the forecaster's own chance of this, stated with the estimate: 70%; the middle value lies on the limit itself.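

Compound 3, like compound 1, gives only a limit of the assay and no number, so the change to trifluoromethyl in place of hydrogen yields no readable step between them. All the values shown sit together: the limit of > 20000 nM in this assay, at which 3 of the 3 values shown sit. The compounds shown leave open whether any change to the shared core would bring a measurable value.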